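A few compounds are considered here, and "the series" means these few. Any claim that something is new, unique, unknown or untested is made for them only; others in the source may bear on it.

This account concerns a small set of sulfonamides tested in an assay on U-87MG ATCC cells for inhibition of RAC-alpha serine/threonine-protein kinase (Homo sapiens), read by AlphaScreen, with a stated time of 2 h; a lower number here means a stronger inhibitor, a higher number a weaker inhibitor. Compound 1 `O=S(=O)(Nc1cc(-c2ccc3ncoc3c2)cnc1Cl)c1ccc(F)cc1` carries a 1,3-benzoxazol-6-yl group on the shared core. In this assay compound 1 gives > 12000 nM, and this is a limit of the assay rather than a measured number. Among the values shown, compound 1 stands at the limit of > 12000 nM in this assay, at which 1 of the 2 values shown sits. Compound 2 `Nc1nc2ccc(-c3cnc(Cl)c(NS(=O)(=O)c4ccc(F)cc4)c3)cc2s1` is the other measured member, and in this assay compound 2 gives 44 nM. Within the data shown here, no pair of measured compounds differs in a single place, so no step between them can be stated, and the two values can only be set side by side.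

Compound 3 `O=S(=O)(Nc1cc(-c2ccc3sncc3c2)cnc1Cl)c1ccc(F)cc1` has not been measured. It differs from compound 1 in one place: a group of 9 heavy atoms (7 carbon, 1 nitrogen, 1 sulfur; one five-membered aromatic ring with 2 hetero atoms, one six-membered aromatic ring of carbon only) in place of a group of 9 heavy atoms (7 carbon, 1 nitrogen, 1 oxygen; one five-membered aromatic ring with 2 hetero atoms, one six-membered aromatic ring of carbon only), on an aromatic carbon The entering group keeps the same two-ring pattern, with sulfur where the leaving group has oxygen. Among the measured compounds shown here, because compound 1 stands at the limit of > 12000 nM in this assay, at which 1 of the 2 values shown sits, the numbers give no direction for this step. The step from compound 1 to compound 3 is expected to be an at least 1.5-fold lower number from compound 1 to compound 3 (0.17 log units; that floor lies within the scatter), a modest change at most. Compound 3 is expected to give 8000 nM, estimated within a range from 1500 nM to 25000 nM.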

Compound 3, half-maximal inhibitory concentration: > 12000 nM
Compound 3 ended at the assay's limit (the forecaster's own chance of this, stated with the estimate: 50%); at least 1.5-fold (0.17 log units) between middle value and limit.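

In this assay, among these compounds, compound 1 and compound 3 both end at a limit of the assay rather than at a measured number, so no step from one to the other can be read. As far as these compounds go, what stays open is how far each compound lies past that limit, and whether sulfur in place of oxygen changes the number at all.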